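This account rests on a few compounds, and the source may have more. Where it says the series, first, only, none or still open, it means among the compounds named here.

Compound 1 `CC1(C)CC(NC(=O)Nc2ccccc2)c2cc(Cl)ccc2O1` gives 7800 nM in a functional assay (aorta) with Rattus norvegicus as the target; on this read-out lower numbers stand for an effect already at smaller amounts and higher numbers for an effect only at larger amounts of compound. Compound 2 `COc1ccc(NC(=O)NC2CC(C)(C)Oc3ccc(Cl)cc32)cc1` reaches only the limit of this assay, > 30000 nM. Compound 3 `CC1(C)CC(NC(=O)Nc2ccc(Cl)cc2)c2cc(F)ccc2O1` also reaches only the limit of this assay, > 30000 nM.

Compound 3 therefore stands at the top edge of what this assay reports; two of the three measured compounds sit there, as the shared limit shows (the limit of > 30000 nM in this assay, at which 2 of the 3 values shown sit). Compound 4 `CC1(C)CC(NC(=O)Nc2ccc(Cl)cc2)c2cc(Cl)ccc2O1` differs from compound 3 by chloro in place of fluoro on an aromatic carbon. Among the compounds with values here, the only measured step, an at least 3.8-fold higher number from compound 1 to compound 2 (0.58 log units; beyond the scatter), concerns a different change on a different ring and so says little about swapping one halogen for another. Compound 1 and compound 3 differ in two places at once, so their values can only be set side by side: compound 1 gives a number, compound 3 only a limit. Within the data shown here, with no step of the same kind to lean on, the expectation is that chloro behaves much like fluoro here, and compound 4 is estimated to move by an at least 1.5-fold lower number from compound 3 to compound 4 (0.17 log units; that floor lies within the scatter). The estimate for compound 4 is thus 20000 nM, with a range from 5000 nM to 60000 nM.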

Compound 4, half-maximal effective concentration: > 300000 nM
Compound 4: no number, only a limit; the forecaster's own chance of this, stated with the estimate: 50%; middle value at least 15-fold (1.17 log units) from the limit.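

Putting chloro in place of hydrogen on the carbon where compound 2 carries its methoxy costs a great deal (an at least 38-fold higher number from compound 1 to compound 4 (1.58 log units; beyond the scatter)). Methoxy on that carbon points the same way (an at least 3.8-fold higher number from compound 1 to compound 2 (0.58 log units; beyond the scatter)), so among compounds 1, 2 and 4 both groups placed there give a higher number than hydrogen, and none of the three goes against this. Limits stand at both ends of the steps from compound 3 and from compound 2 to compound 4, so those steps cannot be read, and compound 4 itself gives only a limit in this assay: the limit of > 300000 nM in this assay, at which 1 of the 4 values shown sits.

On these data alone, whether chloro or fluoro on the core makes any difference therefore stays open. Also open, as far as these compounds go, is whether an amine or a carboxylic acid on that same carbon would keep a measurable number like that of compound 1 (7800 nM) or lose it too.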